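The compounds below may be only part of what the source reports. "The series", "measured", "known", "first", "only" and "open" are said of these compounds alone.

Measured compounds:
- compound 1 `Cc1ncnc2c1c(-c1ccoc1)cn2[C@@H]1O[C@H](CO)[C@@H](O)[C@H]1O`, 89200 nM
- compound 2 `Cc1ncnc2c1c(-c1cccs1)cn2[C@@H]1O[C@H](CO)[C@@H](O)[C@H]1O`, > 100000 nM (a limit of the assay)
- compound 3 `CSc1ncnc2c1c(-c1ccoc1)cn2[C@@H]1O[C@H](CO)[C@@H](O)[C@H]1O`, 98800 nM

In an ADME assay on BJ cells (Homo sapiens), read by MTT assay, with a stated time of 72 h (on this read-out higher numbers stand for weaker inhibition and lower numbers for stronger inhibition), compound 1 gives 89200 nM. Compound 2 reaches only a limit of the assay, > 100000 nM. Compound 3 gives 98800 nM; the change from compound 1 is methylsulfanyl in place of methyl on an aromatic carbon, with a 1.1-fold higher number from compound 1 to compound 3 (0.04 log units; within the scatter). The change from compound 1 to compound 2 is thiophen-2-yl in place of furan-3-yl on an aromatic carbon, with an at least 1.1-fold higher number from compound 1 to compound 2 (0.04 log units; that floor lies within the scatter); compound 2 sits at the limit (the limit of > 100000 nM in this assay, at which 1 of the 3 values shown sits). Compound 4 `CSc1ncnc2c1c(-c1cccs1)cn2[C@@H]1O[C@H](CO)[C@@H](O)[C@H]1O` is not yet measured. It differs from compound 3 by thiophen-2-yl in place of furan-3-yl on an aromatic carbon, the same change, at a place described in the same words. For compound 4 in this assay a step of a 1.2-fold higher number from compound 3 to compound 4 (0.07 log units; within the scatter) is expected, resting on compound 3 at 98800 nM and on the step of an at least 1.1-fold higher number from compound 1 to compound 2 (0.04 log units; that floor lies within the scatter). Compound 4 is estimated at 115000 nM, between 75000 nM and 220000 nM, quite possibly reported only as a limit.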

Compound 4, half-maximal inhibitory concentration: 96900 nM
Estimate against measurement, compound 4: 1.2-fold (0.07 log units) above; the range from low to high includes it.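

In this assay, thiophen-2-yl in place of furan-3-yl, with methylsulfanyl already present, gives a 1.0-fold lower number from compound 3 to compound 4 (0.01 log units; within the scatter), and methylsulfanyl in place of methyl, with thiophen-2-yl already present, gives an at least 1.0-fold lower number from compound 2 to compound 4 (0.01 log units; that floor lies within the scatter). Neither change moves the number beyond the scatter on either core as far as it can be read, but compound 2 is a limit, so this does not show that the thiophen-2-yl change carries over unaltered: the same change on two cores in this assay, an at least 1.1-fold higher number (0.04 log units; that floor lies within the scatter) from compound 1 to compound 2 and a 1.0-fold lower number (0.01 log units; within the scatter) from compound 3 to compound 4; the limit leaves it open whether they differ The methylsulfanyl change stands the same way: the same change on two cores in this assay, a 1.1-fold higher number (0.04 log units; within the scatter) from compound 1 to compound 3 and an at least 1.0-fold lower number (0.01 log units; that floor lies within the scatter) from compound 2 to compound 4; the limit leaves it open whether they differ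

The compounds shown leave open whether any group at these two places moves the number beyond the scatter. An amine or a longer alkyl chain in place of methylsulfanyl, or a carboxylic acid on the five-membered aromatic ring, remains an open case.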